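Aryl exchange on the amide of compound 3

This account rests on a few compounds, and the source may have more. Where it says the series, first, only, none or still open, it means among the compounds named here.

Compound 1 `COc1cc(N(Cc2nc3ccccc3[nH]2)S(=O)(=O)c2ccc(F)cc2)cc(OC)c1OC` gives 7990 nM in a functional assay on PC-3 cells (Homo sapiens) for inhibition, read by MTT assay, with a stated time of 48 h; a higher number here means a weaker inhibitor, a lower number a stronger inhibitor. Compound 2 `COc1cc(N(Cc2nc3ccccc3[nH]2)S(=O)(=O)c2ccccc2Cl)cc(OC)c1OC` gives 34500 nM in this assay, the step being a 4.3-fold higher number from compound 1 to compound 2 (0.64 log units; beyond the scatter). Compound 3 `COc1cc(N(Cc2nc3ccccc3[nH]2)C(=O)c2cccc(Cl)c2)cc(OC)c1OC` carries a carbonyl instead of a sulfonyl on the ring nitrogen. In this assay compound 3 reaches only a limit of the assay, > 50000 nM. Within the data shown here, that is the one value sitting at the limit of > 50000 nM in this assay, at which 1 of the 3 values shown sits. The steps of an at least 6.2-fold higher number from compound 1 to compound 3 (0.79 log units; beyond the scatter) and an at least 1.4-fold higher number from compound 2 to compound 3 (0.16 log units; that floor lies within the scatter) therefore carry only a floor, and compound 3 stands with a limit rather than a number.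

Compound 4 `COc1ccc(C(=O)N(Cc2nc3ccccc3[nH]2)c2cc(OC)c(OC)c(OC)c2)cc1OC` differs from compound 3 by 3,4-dimethoxyphenyl in place of 3-chlorophenyl on a carbonyl carbon. Among the measured compounds shown here, none of the measured steps alters the aryl group on a carbonyl carbon; the nearest comparison, a 4.3-fold higher number from compound 1 to compound 2 (0.64 log units; beyond the scatter), exchanges the aryl on a sulfonyl sulfur and raised the number. No direct guide exists and the starting point is a limit. The expectation for compound 4 is therefore no step beyond the scatter, a number no higher from compound 3 to compound 4 (the limit leaves the size open), most likely again at or past the limit. Compound 4 is estimated at 50000 nM, within a range from 15000 nM to 160000 nM.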

Compound 4, half-maximal inhibitory concentration: 34900 nM
The estimate for compound 4 lay 1.4-fold (0.16 log units) above the measured number, and the stated range covers the measured number.
By their numbers in this assay, from the lowest: compound 1; then compounds 2 and 4 (each within the scatter of the next). At a limit, above all of these: compound 3.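

Exchanging 3-chlorophenyl for 3,4-dimethoxyphenyl on a carbonyl carbon is the only aryl change shown at this position, and in this assay the step is an at least 1.4-fold lower number from compound 3 to compound 4 (0.15 log units; that floor lies within the scatter). Compound 4 thus gives the amide pair a measured number rather than a limit, but the floor of this step does not establish any real difference between the two aryl groups. The true size of the step cannot be read because compound 3 holds only a limit: the limit of > 50000 nM in this assay, at which 1 of the 4 values shown sits.

From the compounds shown here alone, it remains open how an aryl group carrying a single methoxy, a hydroxyl, a dimethylamino group or a carboxylic acid would read on this carbonyl carbon. Also open, going by these compounds, is whether 3,4-dimethoxyphenyl on a sulfonyl sulfur would give a number close to that of compound 4.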